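A few compounds are considered here, and "the series" means these few. Any claim that something is new, unique, unknown or untested is made for them only; others in the source may bear on it.

Compound 3 `COc1cccc(NS(=O)(=O)c2ccc(N3CCNC3=O)cc2)c1` sits in the middle of the three measured compounds in a functional assay on MCF7 cells (Homo sapiens) for antiproliferative activity, read by sulforhodamine B assay, with a stated time of 48 h; a higher number here means a weaker inhibitor, a lower number a stronger inhibitor: compound 3 gives 120 nM, second highest of the three numbers. Its nearest neighbour is compound 1 `O=C1NCCN1c1ccc(S(=O)(=O)Nc2cccc(Br)c2)cc1`, which in this assay gives 100 nM; the two differ by a 1.2-fold higher number from compound 1 to compound 3 (0.08 log units; within the scatter), a gap that lies within the scatter. The furthest is compound 2 `O=C1NCCN1c1ccc(S(=O)(=O)Nc2ccc(I)cc2)cc1`, which in this assay gives 600 nM, a step of a 5.0-fold lower number from compound 2 to compound 3 (0.70 log units; beyond the scatter), well beyond the scatter.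

Compound 4 `O=C1NCCN1c1ccc(S(=O)(=O)Nc2cccc(Cl)c2)cc1` has not yet been measured. It differs from compound 3 by chloro in place of methoxy on an aromatic carbon.

Among the measured compounds shown here, the step that bears most directly on this change is the one between compound 1 and compound 3, where bromo gave way to methoxy at the same position with a result of a 1.2-fold higher number from compound 1 to compound 3 (0.08 log units; within the scatter), within the scatter. Chloro, like bromo, is a single halogen atom, so the reverse exchange is not expected to carry compound 4 far from compound 3. The larger moves seen here, a 6.0-fold higher number from compound 1 to compound 2 (0.78 log units; beyond the scatter) and a 5.0-fold lower number from compound 2 to compound 3 (0.70 log units; beyond the scatter), involve a shift from the 3-substituted to the 4-substituted phenyl and do not speak to the present change. Compound 4 is therefore expected to stay within the scatter of compound 3, a step of about a 1.1-fold lower number from compound 3 to compound 4 (0.04 log units; within the scatter). Compound 4 is estimated at 110 nM, with a range from 50 nM to 250 nM.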

Compound 4, half-maximal inhibitory concentration: 79 nM
Compound 4: the middle estimate sits 1.4-fold (0.14 log units) above what was measured, within the range that was stated.
By their numbers in this assay, from the lowest: compounds 4, 1 and 3 (each within the scatter of the next); then compound 2.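

In this assay, this aromatic carbon now carries chloro, bromo or methoxy, and every exchange among them stays inside the scatter: chloro in place of methoxy gives a 1.5-fold lower number from compound 3 to compound 4 (0.18 log units; within the scatter), and chloro in place of bromo gives a 1.3-fold lower number from compound 1 to compound 4 (0.10 log units; within the scatter). Among the compounds shown here, the single bromo-to-methoxy pair could only hint at this, whereas a second halogen now reads the same as methoxy, even though methoxy brings one more heavy atom and a hydrogen-bond acceptor. The gap to the 4-iodophenyl compound also recurs with the 3-chlorophenyl group, at a 7.6-fold lower number from compound 2 to compound 4 (0.88 log units; beyond the scatter), so compound 1, compound 3 and compound 4 all stand clearly apart from compound 2, which has no exception among the compounds shown.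

No measurement here bears on why these groups read alike or why compound 2 stands apart. Still open, from the compounds shown here alone, is whether that gap follows the iodo group or its place on the ring, which a 4-chlorophenyl partner would help separate, and whether a quite different group at this carbon, such as an amine or a carboxylic acid, would hold the same level.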